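Aryl swaps on the benzylamine arm of a nucleoside core

The source may report more compounds than this note shows. Statements on the series, on what has been measured and on what is new or still open speak of the compounds shown alone.

Measured so far:
Compound 1, `OC[C@H]1O[C@@H](n2cnc3c(NCc4cccc(F)c4)ncnc32)[C@H](O)[C@@H]1O`: 920 nM
Compound 2, `COc1cc(CNc2ncnc3c2ncn3[C@@H]2O[C@H](CO)[C@@H](O)[C@H]2O)cc(OC)c1`: 20200 nM

In a functional assay on HL-60 cells (Homo sapiens) for antiproliferative activity, with a stated time of 72 h (on this read-out higher numbers stand for weaker inhibition and lower numbers for stronger inhibition), compound 2 gives 20200 nM, the highest of the two numbers seen; its nearest neighbour is compound 1, and the step of a 22-fold higher number from compound 1 to compound 2 (1.34 log units; beyond the scatter) is large, showing that the group carried on the saturated chain carbon bound to a nitrogen on an aromatic ring strongly moves the read-out. Compound 3, `COc1cccc(CNc2ncnc3c2ncn3[C@@H]2O[C@H](CO)[C@@H](O)[C@H]2O)c1O`, changes that same group again: 2-hydroxy-3-methoxyphenyl in place of 3,5-dimethoxyphenyl on a saturated chain carbon bound to a nitrogen on an aromatic ring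

For the measured compounds named here, the single measured step bears on this change only indirectly, since no measured compound carries the incoming group. It does show that substituent pattern on that ring can shift the result far beyond the scatter, in either direction. Compound 3 is estimated at 8000 nM, within 1500 nM to 40000 nM, which means an expected step of a 2.5-fold lower number from compound 2 to compound 3 (0.40 log units; beyond the scatter), with wide uncertainty.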

Compound 3, half-maximal inhibitory concentration: 150 nM
For compound 3 the middle estimate is 53-fold (1.73 log units) above the measured one; measured number below the stated range.
By their numbers in this assay, from the lowest: compound 3; then compound 1; then compound 2.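

In this assay the step of a 130-fold lower number from compound 2 to compound 3 (2.13 log units; beyond the scatter) shows that this position can also lower the number sharply, whereas the earlier pair showed only a rise. The step of a 6.1-fold lower number from compound 1 to compound 3 (0.79 log units; beyond the scatter) shows that 2-hydroxy-3-methoxyphenyl also outperforms 3-fluorophenyl here, leaving compound 3 with the lowest number of the three, beyond the scatter from both others. The incoming group carries 1 hydrogen-bond donor where 3,5-dimethoxyphenyl carries 0, but no measurement links this or any other feature to the shift.

As far as these compounds go, the hydroxy and methoxy groups arrive together in compound 3, so their separate contributions remain unknown. A phenyl ring bearing only one of them would help separate the two, and an amine or a carboxylic acid in place of the hydroxy group remains an open question.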